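The compounds below may be only part of what the source reports. "The series", "measured", "known", "first", "only" and "open" are said of these compounds alone.

Compound 1 `O=c1cc(-c2ccccc2)oc2cc(N3COc4c(cccc4[N+](=O)[O-])C3)ccc12`: 1.96%
Compound 2 `Cc1ccc2c(c1)CN(c1ccc3oc(-c4ccccc4)cc(=O)c3c1)CO2`: 31%

In a functional assay on MCF7 cells (Homo sapiens) for inhibition, read by MTT assay, with a stated time of 48 h, tested at 15 ug/mL (on this read-out higher numbers stand for more inhibition of growth at the one concentration tested and lower numbers for less inhibition of growth), compound 1 gives 1.96%, the lower of the two numbers; compound 2 gives 31%, higher by an amount beyond the scatter. Compound 3 `O=c1cc(-c2ccccc2)oc2cc(N3COc4ccccc4C3)ccc12` differs from compound 1 by hydrogen in place of nitro on an aromatic carbon. Going by the values given here, no measured pair shows this change on its own, so its size is open; the two measured compounds do not bracket it. Compound 3 is expected to sit somewhat higher than compound 1, a number 10 percentage points higher from compound 1 to compound 3 (within the scatter), a step that may still fall within the scatter. Compound 3 is estimated at 12%, range 0% to 32%.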

Compound 3, percent growth inhibition at one concentration: 3.89%
Compound 3: the middle estimate sits 8.1 percentage points above what was measured; low and high end bracket the measured number.
By their numbers in this assay, from the lowest: compounds 1 and 3 (each within the scatter of the next); then compound 2.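

In this assay the swap of nitro for hydrogen on this aromatic carbon gives a number 1.9 percentage points higher from compound 1 to compound 3 (within the scatter) and so does not separate the two groups at this position. The low reading of compound 1 therefore cannot be assigned to the nitro group, since compound 3 lacks it and reads alike. No measurement at hand accounts for this result.

Going by these compounds, whether an amine or a carboxylic acid on this same aromatic carbon would read apart from hydrogen stays open. Also open, on these data alone, is whether a methoxy group would behave like nitro here.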